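From Furan-2-yl to 1-Benzofuran-2-yl at the Assay Limit

The source may report more compounds than this note shows. Statements on the series, on what has been measured and on what is new or still open speak of the compounds shown alone.

In a functional assay on K562 cells (Homo sapiens), read by MTT assay, with a stated time of 72 h (a higher number here means a weaker inhibitor, a lower number a stronger inhibitor), compound 1 `CNc1ncnc2c1c(-c1ccsc1)cn2[C@@H]1O[C@H](CO)[C@@H](O)[C@H]1O` gives > 20000 nM, which is a limit of the assay. Compound 2 `Nc1nc(N)c2c(-c3ccco3)cn([C@@H]3O[C@H](CO)[C@@H](O)[C@H]3O)c2n1` also gives a limit, > 20000 nM. Compound 3 `Cc1nc(N)c2c(-c3ccco3)cn([C@@H]3O[C@H](CO)[C@@H](O)[C@H]3O)c2n1` likewise stands only at a limit, > 20000 nM. All three compounds share (the limit of > 20000 nM in this assay, at which 3 of the 3 values shown sit). Among the measured compounds shown here, the one measured step is a step that the two limits leave unreadable from compound 2 to compound 3, so it offers no size to carry forward. Compound 4 `Cc1nc(N)c2c(-c3cc4ccccc4o3)cn([C@@H]3O[C@H](CO)[C@@H](O)[C@H]3O)c2n1` differs from compound 3 by 1-benzofuran-2-yl in place of furan-2-yl on an aromatic carbon, with 1-benzofuran-2-yl in place of furan-2-yl. For the measured compounds named here, no measured step bears on this change, so no clear shift in this assay is expected, and any movement would most likely be towards a stronger inhibitor. The expected step is a number no higher from compound 3 to compound 4 (the limit leaves the size open). For compound 4 the estimate is 20000 nM, with an expected range of 6000 nM to 40000 nM.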

Compound 4, half-maximal inhibitory concentration: 4990 nM
Estimate against measurement, compound 4: 4.0-fold (0.60 log units) above; the whole stated range lies above it.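

In this assay, 1-benzofuran-2-yl in place of furan-2-yl gives an at least 4.0-fold lower number from compound 3 to compound 4 (0.60 log units; beyond the scatter), the first step among these compounds whose direction and minimum size can be read. Compound 4 alone stands clear of the limit that holds the others: the limit of > 20000 nM in this assay, at which 3 of the 4 values shown sit. The aromatic carbon on the five-membered ring therefore accepts the added six-membered aromatic ring of carbon only, and the change there registers in this assay.

On these data alone, the true size of the step stays open, as does whether it would carry over to the amino group of compound 2. Also open, as far as these compounds go, is what a phenyl group or a naphthalen-2-yl group would give at this position.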